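Compound 3 to compound 4: working notes on cytotoxicity

The compounds below may be only part of what the source reports. "The series", "measured", "known", "first", "only" and "open" are said of these compounds alone.

In an ADME assay on HepG2 2.2.15 cells (Homo sapiens) for cytotoxicity (a lower number here means that less compound is tolerated, a higher number that more compound is tolerated), compound 1 `N#CCC(=O)OCCc1c(-c2ccccc2Cl)c2cc(Cl)ccc2[nH]c1=O` gives 100000 nM as a measured number. Compound 2 `COc1cccc(/C=C/C(=O)OCCc2c(-c3ccccc3Cl)c3cc(Cl)ccc3[nH]c2=O)c1` gives > 1300000 nM and this is a limit of the assay. Compound 3 `O=C(/C=C/c1cccc(C(F)(F)F)c1)OCCc1c(-c2ccccc2Cl)c2cc(Cl)ccc2[nH]c1=O` gives > 1400000 nM and this too is only a limit, so its standing is not a number.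

Compound 4 `C/C=C/C=C/C(=O)OCCc1c(-c2ccccc2Cl)c2cc(Cl)ccc2[nH]c1=O` differs from compound 3 by prop-1-en-1-yl in place of 3-(trifluoromethyl)phenyl on a double-bonded chain carbon bound to a double-bonded chain carbon and the same difference reads 2-(3-(trifluoromethyl)phenyl)ethenyl to penta-1,3-dien-1-yl. The steps bearing on this are an at least 13-fold higher number from compound 1 to compound 2 (1.11 log units; beyond the scatter) and an at least 14-fold higher number from compound 1 to compound 3 (1.14 log units; beyond the scatter) and both are large, each with a phenyl-bearing ethenyl group in place of cyanomethyl. There is also a step that the two limits leave unreadable from compound 2 to compound 3 and it adds no size.

Compound 4 keeps the ethenyl link but loses the aromatic ring, so only part of the rise seen in an at least 14-fold higher number from compound 1 to compound 3 (1.14 log units; beyond the scatter) is expected to survive in this assay. The expected change is an at least 2.3-fold lower number from compound 3 to compound 4 (0.36 log units; beyond the scatter) and a modest move to a lower number is the direction estimated. For compound 4 the estimated value is 600000 nM with an expected range of 150000 nM to 1500000 nM and a limit instead of a number would be no surprise.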

Compound 4, half-maximal cytotoxic concentration: 440000 nM
The estimate for compound 4 lay 1.4-fold (0.13 log units) above the measured number; measured number inside the range.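

In this assay, compound 4 shows that this position still responds once the aromatic ring is gone, and it returns a number rather than a limit: prop-1-en-1-yl gives an at least 3.1-fold lower number from compound 3 to compound 4 (0.50 log units; beyond the scatter) and an at least 2.9-fold lower number from compound 2 to compound 4 (0.47 log units; beyond the scatter). With no ring present, penta-1,3-dien-1-yl still gives a 4.4-fold higher number from compound 1 to compound 4 (0.64 log units; beyond the scatter), so part of the rise over cyanomethyl does not require an aromatic ring. The step between compound 2 and compound 3 cannot be read, and the step to compound 4 is only a minimum, as compound 3 stands only as a limit: the limit of > 1400000 nM in this assay, at which 1 of the 4 values shown sits.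

As far as these compounds go, it remains open how much of the rise depends on the double bonds and how much on the aromatic ring. A saturated pentyl chain in place of penta-1,3-dien-1-yl, or an amine on the phenyl ring, would test this further.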